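The compounds below may be only part of what the source reports. "The series", "measured", "known", "first", "only" and "open" are said of these compounds alone.

Measured so far:
compound 1, `Oc1nnc(-c2ccc(N3CCC(Oc4ccccc4C(F)(F)F)CC3)nn2)s1` — in an assay on microsomes from liver for inhibition of acyl-CoA desaturase 1 (Rattus norvegicus) (on this read-out lower numbers stand for stronger inhibition and higher numbers for weaker inhibition), compound 1 gives 6.1 nM
compound 2, `CC(C)Cc1nnc(-c2ccc(N3CCC(Oc4ccccc4C(F)(F)F)CC3)nn2)s1` — in this assay compound 2 gives 37 nM

Compound 2 stands at the highest of the two numbers; its nearest neighbour is compound 1, from which a 6.1-fold higher number from compound 1 to compound 2 (0.78 log units; beyond the scatter). Within the data shown here, that single step, isobutyl in place of hydroxy on an aromatic carbon of the five-membered ring, is the only measured change in this pair, and it was modest but beyond the scatter.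

Compound 3, `OCc1nnc(-c2ccc(N3CCC(Oc4ccccc4C(F)(F)F)CC3)nn2)o1`, is not yet measured. It differs from compound 2 in this way: 5-(hydroxymethyl)-1,3,4-oxadiazol-2-yl in place of 5-isobutyl-1,3,4-thiadiazol-2-yl on an aromatic carbon. The entering group carries one hydrogen-bond donor and four acceptors, where the leaving group had none and three; in that respect compound 3 resembles compound 1 more than compound 2. Among the measured compounds shown here, the step from compound 1 to compound 2 bears on the change, since it removed a hydroxy and lost a donor with a higher number; the swap of sulfur for oxygen in the ring has no measured counterpart here. Compound 3 is therefore expected to move back toward compound 1, with a 3.7-fold lower number from compound 2 to compound 3 (0.57 log units; beyond the scatter), though less surely than a direct return would be. The estimate for compound 3 in this assay is 10 nM, within 3 nM to 40 nM.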

Compound 3, half-maximal inhibitory concentration: 2.9 nM
Beside the measured number, compound 3's estimate is 3.4-fold (0.54 log units) above it; measured number below the stated range.
By their numbers in this assay, from the lowest: compound 3; then compound 1; then compound 2.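

Among these compounds, at this place, on an aromatic carbon of a six-membered aromatic ring with 2 nitrogen, this assay responds strongly to the group carried there: 5-(hydroxymethyl)-1,3,4-oxadiazol-2-yl in place of 5-isobutyl-1,3,4-thiadiazol-2-yl gives a 13-fold lower number from compound 2 to compound 3 (1.11 log units; beyond the scatter), a large step that the single earlier step had not suggested. The same group in place of 5-hydroxy-1,3,4-thiadiazol-2-yl gives a 2.1-fold lower number from compound 1 to compound 3 (0.32 log units; beyond the scatter), so the position accepts an oxadiazole as well as a thiadiazole, and among these three compounds the sulfur-containing ring is not needed for the lowest number. Among these three compounds, the two whose groups carry a hydroxy sit below compound 2, but nothing measured here accounts for these steps.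

The step from compound 2 to compound 3 changes the ring and its substituent together, so the share of each stays unresolved. A 5-isobutyl-1,3,4-oxadiazol-2-yl or a 5-(hydroxymethyl)-1,3,4-thiadiazol-2-yl group would separate the two, while a 5-(aminomethyl)-1,3,4-oxadiazol-2-yl group or a carboxylic acid on the oxadiazole would test whether the hydroxy itself can be exchanged.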